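The source may hold more compounds than are shown below. What is called first, only, known or untested is meant among the compounds shown, and "the series" means these compounds.

In a toxicity assay on HepG2 cells (Homo sapiens) for inhibition, read by resazurin assay, with a stated time of 24 h (on this read-out higher numbers stand for lower toxicity in this test and lower numbers for higher toxicity in this test), three compounds sharing one core were measured: compound 1 (`NC(=O)c1nc([N+](=O)[O-])cn1Cc1ccc(OC(F)(F)F)cc1`), compound 2 (`NC(=O)c1nc([N+](=O)[O-])cn1Cc1ccccn1`) and compound 3 (`NC(=O)c1nc([N+](=O)[O-])cn1CC1CCCCC1`). Compound 1 gives > 100000 nM as a limit of the assay and not a number. Compound 2 gives > 100000 nM as a limit too. Compound 3 gives > 100000 nM as a limit as well. It therefore stands with the other two, as the limit of > 100000 nM in this assay, at which 3 of the 3 values shown sit, shows. Compound 4 (`NC(=O)c1nc([N+](=O)[O-])cn1CC1CC1`) differs from compound 3 by cyclopropyl in place of cyclohexyl on a saturated chain carbon bound to an aromatic nitrogen and carries cyclopropyl in place of cyclohexyl on a saturated chain carbon bound to an aromatic nitrogen. For the measured compounds named here, the one measured step at this place is a step that the two limits leave unreadable from compound 2 to compound 3 and it gives no size to carry over. With all three compounds at one limit, no step beyond the scatter is expected in this assay in either direction. The estimated change is a number no higher from compound 3 to compound 4 (the limit leaves the size open) and no more. Compound 4 is expected at 100000 nM with an estimated range from 60000 nM to 150000 nM in this test.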

Compound 4, half-maximal cytotoxic concentration: > 100000 nM
Compound 4: a limit, no number (the forecaster's own chance of this, stated with the estimate: 85%); the middle value sits exactly at the limit.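

Neither the step from compound 2 to compound 4 nor that from compound 3 to compound 4 can be read in this assay, because each compound gives a limit and no number: the limit of > 100000 nM in this assay, at which 4 of the 4 values shown sit.

The compounds shown leave open how the four rank against one another, and whether any group at this place would give a number instead of a limit.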